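Nitro for cyano on a second core

The source may hold more compounds than are shown below. What is called first, only, known or untested is meant among the compounds shown, and "the series" means these compounds.

Compound 1 `CC(O)(CSc1ccc(S(F)(F)(F)(F)F)cc1)C(=O)Nc1ccc(C#N)cc1C(F)(F)F` and compound 2 `CC(O)(CSc1ccc(S(F)(F)(F)(F)F)cc1)C(=O)Nc1ccc([N+](=O)[O-])cc1C(F)(F)F` share one core and differ by one group (nitro in place of cyano on an aromatic carbon). In a functional assay on CWR22R cells (Homo sapiens) for antiproliferative activity, read by propidium iodide staining, with a stated time of 96 h (on this read-out lower numbers stand for stronger inhibition and higher numbers for weaker inhibition), compound 1 gives 13200 nM and compound 2 gives 13100 nM, a step of a 1.0-fold lower number from compound 1 to compound 2 (0.00 log units; within the scatter).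

Compound 3 `CC(O)(CS(=O)(=O)c1ccc(S(F)(F)(F)(F)F)cc1)C(=O)Nc1ccc(C#N)cc1C(F)(F)F` carries the cyano group of compound 1 on a different core; the difference between the two cores is not broken down here. In this assay compound 3 gives 19400 nM, which lies within the scatter of both compound 1 and compound 2, so no order among the three measured compounds can be read from these numbers.

Compound 4 `CC(O)(CS(=O)(=O)c1ccc(S(F)(F)(F)(F)F)cc1)C(=O)Nc1ccc([N+](=O)[O-])cc1C(F)(F)F` is not yet measured. It stands to compound 3 as compound 2 stands to compound 1: nitro in place of cyano on an aromatic carbon, at a place described in the same words in both pairs, so the change is the same one, made here on the core of compound 3.

The expectation rests on a single earlier instance. Because the step of a 1.0-fold lower number from compound 1 to compound 2 (0.00 log units; within the scatter) was flat, the step from compound 3 to compound 4 in this assay is expected to be of the same size, a 1.0-fold lower number from compound 3 to compound 4 (0.01 log units; within the scatter), and is expected to stay within the scatter. Among the measured compounds shown here, on that basis compound 4 is estimated at 19000 nM in this assay, with a likely range from 9000 nM to 40000 nM; the range is kept wide since only one measured pair supports the transfer of this change onto the core of compound 3.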

Compound 4, half-maximal inhibitory concentration: 18700 nM
For compound 4 the middle estimate is 1.0-fold (0.01 log units) above the measured one, and the stated range covers the measured number.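

Nitro in place of cyano on the second core gives a 1.0-fold lower number from compound 3 to compound 4 (0.02 log units; within the scatter) in this assay, so the swap leaves the number as flat there as it was on the first core. The two steps agree, and on these two cores the change carries over without a difference that can be read: the same change on two cores in this assay, a 1.0-fold lower number (0.00 log units; within the scatter) from compound 1 to compound 2 and a 1.0-fold lower number (0.02 log units; within the scatter) from compound 3 to compound 4, 1.0-fold (0.01 log units) apart, within the scatter of two such steps

Among the compounds shown here, this agreement covers only two cores, a single cell assay and a change that moves the number by no more than the scatter on either core, so it shows that a flat result repeated, not that a step of real size would transfer in the same way from one core to another; it also gives no reason for the flatness and cannot say whether the same swap would stay flat on a third core.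

The compounds shown leave open whether other groups at this place on the ring, such as an amine, a carboxylic acid or a chlorine atom, would be as silent as cyano and nitro on either core. They also leave open what a sulfoxide link, with a single oxygen on the sulfur, would do to the number in this assay with either cyano or nitro in place.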